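Chloro for hydrogen on the pendant phenyl of compound 2

A few compounds are considered here, and "the series" means these few. Any claim that something is new, unique, unknown or untested is made for them only; others in the source may bear on it.

Compound 2 `Clc1ccc(/C=N/Nc2nc(-c3ccccc3)cs2)c(Cl)c1` is read in a functional assay, read by spectrophotometry, with a stated time of 15 min, tested at 40 ug/mL (a lower number here means a weaker effect, a higher number a stronger effect of the compound at the concentration tested), where compound 2 gives 78.9%, within the scatter of both compound 3 `Clc1ccc(-c2csc(N/N=C/c3cccs3)n2)cc1` at 83.2% and compound 1 `Fc1ccc(-c2csc(N/N=C/c3cccs3)n2)cc1` at 87.5%. Among the compounds with values here, the only step measured in one place, a number 4.3 percentage points lower from compound 1 to compound 3 (within the scatter), compares two halogens on the same aromatic carbon and tells nothing about adding one where hydrogen stood. Compound 4 `Clc1ccc(-c2csc(N/N=C/c3ccc(Cl)cc3Cl)n2)cc1` differs from compound 2 by chloro in place of hydrogen on an aromatic carbon. No measured step bears on this change; the three numbers sit close together and give no reason to expect a move beyond the scatter in this assay. Compound 4 is therefore estimated at 80%, with a range of 68% to 90%, an expected step of a number 1.1 percentage points higher from compound 2 to compound 4 (within the scatter).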

Compound 4, a percentage reported as inhibition, at one concentration (the size of the read-out at that concentration, not a potency): 76.2%
Compound 4: middle estimate off by 3.8 percentage points, on the high side; measured number inside the range.
By their numbers in this assay, from the lowest: compounds 4, 2, 3 and 1 (each within the scatter of the next, the first and the last beyond it).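

In this assay, phenyl to 4-chlorophenyl gives a number 2.7 percentage points lower from compound 2 to compound 4 (within the scatter), so chloro in place of hydrogen on this aromatic carbon, para to a large group, leaves the read-out within the scatter. The fluoro-to-chloro step could not show this, as it only exchanged one halogen for another. Nothing available explains this result.

As far as these compounds go, whether an amine or a carboxylic acid on this carbon would move the read-out beyond the scatter remains open. Also open, from the compounds shown here alone, is whether chloro for hydrogen here would read the same with the other end of the molecule changed.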